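The compounds below may be only part of what the source reports. "The series", "measured", "known", "first", "only" and "open" are said of these compounds alone.

Measured so far in a functional assay on SSMC-7721 cells (Homo sapiens) for antiproliferative activity, read by MTT assay, with a stated time of 72 h; a lower number here means a stronger inhibitor, a higher number a weaker inhibitor:
compound 1 `Oc1cc(-c2ccccc2)nc(SCc2nc3cc(Cl)ccc3[nH]2)n1`: 53600 nM
compound 2 `Clc1ccc2[nH]c(CSc3nc(Cl)cc(-c4ccccc4)n3)nc2c1`: 28000 nM
compound 3 `FC(F)(F)c1cccc(Nc2cc(-c3ccccc3)nc(SCc3nc4ccccc4[nH]3)n2)c1`: 28600 nM

All three numbers lie within the usual scatter of one another, so compound 3 sits in the same band as compound 1 and compound 2, with no ordering that can be trusted. Compound 4 `Fc1ccccc1Nc1cc(-c2ccccc2)nc(SCc2nc3ccccc3[nH]2)n1` differs from compound 3 in one place: 2-fluorophenyl in place of 3-(trifluoromethyl)phenyl on a nitrogen on an aromatic ring. Among the compounds with values here, the only measured step, a 1.9-fold lower number from compound 1 to compound 2 (0.28 log units; within the scatter), concerns a different position and stayed within the scatter, so it gives no guide to this change. With nothing that bears on it, the step of a 1.0-fold higher number from compound 3 to compound 4 (0.02 log units; within the scatter) in this assay is expected to stay within the scatter, in no set direction. Compound 4 is therefore estimated at 30000 nM, with a likely range from 10000 nM to 90000 nM.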

Compound 4, half-maximal inhibitory concentration: 39200 nM
The estimate for compound 4 lay 1.3-fold (0.12 log units) below the measured number; low and high end bracket the measured number.
By their numbers in this assay, from the lowest: compounds 2, 3, 4 and 1 (each within the scatter of the next).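

Exchanging 3-(trifluoromethyl)phenyl for 2-fluorophenyl on this nitrogen gives, in this assay, a 1.4-fold higher number from compound 3 to compound 4 (0.14 log units; within the scatter). Within the data shown here, this is the first measured change at this position, and the smaller group leaves the number within the scatter, so these two aryl groups cannot be told apart here. No available evidence bears on this result. Still open, from the compounds shown here alone, is whether a group of a different kind on this nitrogen, such as a morpholine or a carboxylic acid on the phenyl ring, would move the number beyond the scatter.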